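A few compounds are considered here, and "the series" means these few. Any claim that something is new, unique, unknown or untested is made for them only; others in the source may bear on it.

Measured in a functional assay on DU-145 cells (Homo sapiens) for antiproliferative activity, read by propidium iodide staining, with a stated time of 96 h; on this read-out lower numbers stand for stronger inhibition and higher numbers for weaker inhibition:
compound 1 `CC(O)(CSc1cccc(OC(F)(F)F)c1)C(=O)Nc1ccc(S(F)(F)(F)(F)F)cc1`: 23800 nM
compound 2 `CC(O)(COc1cccc(S(F)(F)(F)(F)F)c1)C(=O)Nc1ccc(C#N)cc1C(F)(F)F`: 16300 nM
compound 3 `CC1(C)C(=O)N(c2ccc([N+](=O)[O-])c(C(F)(F)F)c2)C(=S)N1c1cccc(S(F)(F)(F)(F)F)c1`: 100000 nM

Compound 3 stands highest of the three, and its gaps to compound 1 and compound 2 both lie beyond the scatter. The next compound is compound 4 `CC1(C)C(=O)N(c2ccc(C#N)c(C(F)(F)F)c2)C(=S)N1c1cccc(S(F)(F)(F)(F)F)c1`, with cyano in place of nitro on an aromatic carbon, ortho to a trifluoromethyl group and para to a large group: cyano in place of nitro on an aromatic carbon. For the measured compounds named here, no measured pair isolates this change. In this assay a moderate fall in the number is expected, as compound 3 at 100000 nM sits at the top of the values seen so far. The estimated step is a 2.5-fold lower number from compound 3 to compound 4 (0.40 log units; beyond the scatter). For compound 4 the estimated value is 40000 nM, with an expected range of 13000 nM to 100000 nM.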

Compound 4, half-maximal inhibitory concentration: 100000 nM
Compound 4: the middle estimate sits 2.5-fold (0.40 log units) below what was measured; the measured number falls inside the stated range.
By their numbers in this assay, from the lowest: compounds 2 and 1 (each within the scatter of the next); then compounds 3 and 4 (each within the scatter of the next).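

In this assay, for the compounds shown here, cyano in place of nitro on this aromatic carbon, ortho to a trifluoromethyl group and para to a large group, gives no change at the digits printed from compound 3 to compound 4 (within the scatter) in the first single-place comparison of the series. On this core, the read-out does not separate the two groups at this position. No available evidence explains this result.

As far as these compounds go, it remains open whether an amine or a carboxylic acid on this carbon would shift the number. From the compounds shown here alone, the same exchange on the core of compound 2 also remains open.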